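The compounds below may be only part of what the source reports. "The series", "measured", "known", "first", "only" and "open" are said of these compounds alone.

Of the compounds shown here, three on one shared core have been measured in an assay on membranes from HeLa cells for displacement of a labelled ligand from adenosine receptor A3 (Homo sapiens), read by scintillation counting, with a stated time of 180 min, tested at 1 uM; on this read-out lower numbers stand for less inhibition and higher numbers for more inhibition at the one concentration tested (going by the name of the read-out). Compound 1 `COC(=O)C1=C(C)NC(=O)NC1c1cccs1` gives 3%, compound 2 `CC1=C(C(=O)OCC(C)C)C(c2cccs2)NC(=O)N1` gives 11%, and compound 3 `CCSC(=O)C1=C(C)NC(=O)NC1c1cccs1` gives 1%. Compound 3 stands lowest of the three numbers, but its gap to compound 1 and its gap to compound 2 both lie within the scatter, so no order among the three can be claimed. The step considered now runs from compound 3 to compound 4 `CCC(CC)OC(=O)C1=C(C)NC(=O)NC1c1cccs1`, not yet measured: (pentan-3-yl)oxy in place of ethylsulfanyl on a carbonyl carbon. Among the compounds with values here, two measured steps bear on it, each putting ethylsulfanyl onto the carbonyl carbon in place of an oxygen-linked group: a number 2 percentage points lower from compound 1 to compound 3 (within the scatter) and a number 10 percentage points lower from compound 2 to compound 3 (within the scatter). The reverse exchange, an oxygen-linked group in place of ethylsulfanyl, is thus tied only to movements within the scatter. Lengthening the oxygen-linked chain, a number 8 percentage points higher from compound 1 to compound 2 (within the scatter), was likewise within the scatter. For compound 4 in this assay the estimate is 8%, with a range from 0% to 20%. The expected step of a number 7 percentage points higher from compound 3 to compound 4 (within the scatter) is none beyond the scatter.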

Compound 4, a percentage reported as inhibition, at one concentration (the size of the read-out at that concentration, not a potency): 1%
Compound 4: middle estimate off by 7 percentage points, on the high side; the range from low to high includes it.
By their numbers in this assay, from the lowest: compounds 3, 4, 1 and 2 (each within the scatter of the next).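

Exchanging ethylsulfanyl for (pentan-3-yl)oxy on a carbonyl carbon gives, in this assay, no change at the digits printed from compound 3 to compound 4 (within the scatter), so this branched oxygen-linked group with its 6 heavy atoms does not separate from the sulfur-linked group. Among the oxygen-linked groups, pentan-3-yl in place of isobutyl gives a number 10 percentage points lower from compound 2 to compound 4 (within the scatter), and pentan-3-yl in place of methyl gives a number 2 percentage points lower from compound 1 to compound 4 (within the scatter), so all four groups at this place now lie within the scatter of one another and none of the steps marks out a preferred group. Nothing available here accounts for this flat result.

From the compounds shown here alone, it remains open whether a carboxylic acid, an amide or a longer chain such as octyloxy on this carbonyl carbon would move the number beyond the scatter. Changes elsewhere on the shared core, such as a benzyl group on a ring nitrogen, also remain open.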